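This account rests on a few compounds, and the source may have more. Where it says the series, first, only, none or still open, it means among the compounds named here.

Compound 1 `COc1nc(NC2CC2)c2ncn([C@H]3C[C@H](N=[N+]=[N-])[C@@H](CO)O3)c2n1` is an azide-bearing nucleoside whose safety for cells can be judged from an ADME assay on Vero cells (Chlorocebus sabaeus) for cytotoxicity, with a stated time of 5 days; a lower number here means a stronger inhibitor, a higher number a weaker inhibitor. There, compound 1 gives > 100000 nM, which is a limit of the assay and not a number. Compound 2 `COc1nc(F)nc2c1ncn2[C@H]1C[C@H](N=[N+]=[N-])[C@@H](CO)O1` gives > 100000 nM, which is also a limit. Going by the values given here, the only guide so far is therefore (the limit of > 100000 nM in this assay, at which 2 of the 2 values shown sit).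

Compound 3 `[N-]=[N+]=N[C@H]1C[C@H](n2cnc3c(NC4CC4)nc(N)nc32)O[C@@H]1CO` differs from compound 1 by a single swap: amino in place of methoxy on an aromatic carbon. This puts amino in place of methoxy on an aromatic carbon, between two ring nitrogen atoms. Among the compounds with values here, no measured pair shows what this swap does in this assay, so the expectation is cautious. The expected at least 1.4-fold lower number from compound 1 to compound 3 (0.15 log units; that floor lies within the scatter) is small and points, if anywhere, toward a lower number. Compound 3 may well reach the same limit. If it gives a number, the estimate for compound 3 is 70000 nM, within an expected range of 20000 nM to 100000 nM.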

Compound 3, half-maximal inhibitory concentration: > 100000 nM
Compound 3: a limit, no number; the forecaster's own chance of this, stated with the estimate: 65%; middle value at least 1.4-fold (0.15 log units) away from the limit.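

In this assay compound 3 gives > 100000 nM, a limit of the assay and not a number. Compound 1 also sits at a limit, so the step between compound 1 and compound 3 cannot be read. The compounds shown leave open whether amino in place of methoxy changes the result at all, since all of them share one ceiling: the limit of > 100000 nM in this assay, at which 3 of the 3 values shown sit.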